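The source may report more compounds than this note shows. Statements on the series, on what has been measured and on what is new or still open speak of the compounds shown alone.

In a functional assay on HT-1080 cells (Homo sapiens) for antiproliferative activity, read by sulforhodamine B assay, with a stated time of 48 h (a lower number here means a stronger inhibitor, a higher number a weaker inhibitor), compound 2 `CC(C)c1ccccc1OS(=O)(=O)c1cccc(NC(=O)C(C)(C)C)c1` gives 11000 nM. Its closest measured relative, compound 1 `CCCCCC(=O)Nc1cccc(S(=O)(=O)Oc2ccccc2C(C)C)c1`, gives 11000 nM in this assay, and the step of no change at the digits printed from compound 1 to compound 2 (within the scatter) shows that exchanging pentyl for tert-butyl on the carbonyl carbon left the number where it was. Compound 3 `CC(C)c1ccccc1OS(=O)(=O)c1cccc(NC(=O)CCl)c1` has not yet been measured; it differs from compound 2 in that (chloromethyl in place of tert-butyl on a carbonyl carbon). Within the data shown here, the only measured step that bears on this change is the one from compound 1 to compound 2, which stayed within the scatter, so another exchange of the group on the carbonyl carbon is expected to move the number in this assay little, if at all, in either direction. Compound 3 is therefore estimated to give about 9000 nM, within a range of 2500 nM to 30000 nM, which would mean a step of a 1.2-fold lower number from compound 2 to compound 3 (0.09 log units; within the scatter).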

Compound 3, half-maximal inhibitory concentration: 780 nM
Compound 3: middle estimate off by 12-fold (1.06 log units), on the high side, outside the stated range (below it).
By their numbers in this assay, from the lowest: compound 3; then compounds 1 and 2 (each within the scatter of the next).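

The group on the carbonyl carbon matters more than compounds 1 and 2 suggested. In this assay, chloromethyl in place of tert-butyl gives a 14-fold lower number from compound 2 to compound 3 (1.15 log units; beyond the scatter), and chloro in place of butyl on the saturated chain carbon bound to the carbonyl carbon gives a 14-fold lower number from compound 1 to compound 3 (1.15 log units; beyond the scatter), so pentyl and tert-butyl sit level while chloromethyl stands clearly apart. No measurement here explains this difference.

The compounds shown do not separate the chlorine from the shorter group that carries it: a plain methyl or a bromomethyl on the same carbonyl carbon would tell these apart. From the compounds shown here alone, it also remains open how a longer chloroalkyl chain or an aminomethyl group would behave there.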